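This account rests on a few compounds, and the source may have more. Where it says the series, first, only, none or still open, it means among the compounds named here.

Of the compounds shown here, two have been measured in a functional assay on spleen for antagonist activity at Alpha-1B adrenergic receptor (Rattus norvegicus); on this read-out lower numbers stand for lower potency and higher numbers for higher potency (the scale is a negative logarithm). Compound 1 `COc1cccc(OC)c1OCCNCCOc1ccccc1OCc1ccccc1Cl` gives 7.52, the lowest of the two numbers available. Within the data shown here, compound 2 `COc1ccc(COc2ccccc2OCCNCCOc2c(OC)cccc2OC)cc1` gives 9.51, and the only known step is a number 1.99 log units higher from compound 1 to compound 2 (beyond the scatter), obtained with a 4-methoxyphenyl in place of 2-chlorophenyl on a saturated chain carbon bound to an oxygen on an aromatic ring.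

Compound 3 `COc1cccc(OC)c1OCCNCCOc1ccccc1OCc1ccc(OC(C)C)cc1` has not yet been measured. Its difference from compound 1 is 4-isopropoxyphenyl in place of 2-chlorophenyl on a saturated chain carbon bound to an oxygen on an aromatic ring. The step from compound 1 to compound 2 bears on this change, because the entering group 4-isopropoxyphenyl shares its 4-alkoxy pattern with the 4-methoxyphenyl that produced a number 1.99 log units higher from compound 1 to compound 2 (beyond the scatter). A rise beyond the scatter is therefore expected for compound 3, though its exact size is uncertain with a single precedent. The expected step from compound 1 to compound 3 is a number 1.48 log units higher from compound 1 to compound 3 (beyond the scatter). Compound 3 is estimated at 9, within a range from 8.3 to 9.7.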

Compound 3, negative logarithm of the antagonist equilibrium constant: 8.62
The estimate for compound 3 lay 0.38 log units above the measured number; the measured number falls inside the stated range.
By their numbers in this assay, from the lowest: compound 1; then compound 3; then compound 2.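

In this assay, 4-isopropoxyphenyl in place of 2-chlorophenyl on a saturated chain carbon bound to an oxygen on an aromatic ring gives a number 1.10 log units higher from compound 1 to compound 3 (beyond the scatter) and so the rise at this position is no longer seen with 4-methoxyphenyl alone. The group on that oxygen still matters: isopropyl in place of methyl gives a number 0.89 log units lower from compound 2 to compound 3 (beyond the scatter) and so the larger of these two groups keeps only part of the gain. No measurement is at hand that accounts for either step.

From the compounds shown here alone, it remains open whether 4-ethoxyphenyl would read closer to compound 2 or to compound 3. Also open, going by these compounds, is whether the oxygen is needed at all: 4-isopropylphenyl would test that, and plain phenyl would show how much of the rise comes simply from losing 2-chlorophenyl.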